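Working notes: from compound 2 to compound 3

The source may report more compounds than this note shows. Statements on the series, on what has been measured and on what is new or still open speak of the compounds shown alone.

Measured in a physicochemical assay for lipophilicity, read by HPLC, at pH 7.5; on this read-out lower numbers stand for lower lipophilicity and higher numbers for higher lipophilicity
- compound 1 `CC[C@@H](Nc1c(C#N)c(-c2ccc(-c3ccc(F)cc3)cc2)nc2cnccc12)C(N)=O` at 2.7
- compound 2 `CC[C@@H](Nc1c(C#N)c(-c2ccc(-c3ccccc3N(C)C)cc2)nc2cnccc12)C(N)=O` at 3.2

Compound 2, at 3.2 on this scale, is the higher of the two measured numbers. Compound 3 `CC[C@@H](Nc1c(C#N)c(-c2ccc(-c3cnccc3C)cc2)nc2cnccc12)C(N)=O`, not yet measured, carries 4-methylpyridin-3-yl in place of 2-(dimethylamino)phenyl on an aromatic carbon on the same aromatic carbon. For the measured compounds named here, one measured step bears on this change, at the same place: a number 0.50 log units higher from compound 1 to compound 2 (beyond the scatter) when 2-(dimethylamino)phenyl entered. Going by the values given here, with that group leaving again, a fall of similar or somewhat larger size is expected, and no measured compound tests the entering ring. The expected step is a number 0.80 log units lower from compound 2 to compound 3 (beyond the scatter) in this assay as estimated here. Compound 3 is estimated at 2.4 (range 1.9 to 2.9).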

Compound 3, distribution coefficient: 2
Beside the measured number, compound 3's estimate is 0.40 log units above it; low and high end bracket the measured number.
By their numbers in this assay, from the lowest: compound 3; then compound 1; then compound 2.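

In this assay the entry of 4-methylpyridin-3-yl on this aromatic carbon gives a number 1.20 log units lower from compound 2 to compound 3 (beyond the scatter) and, against the 4-fluorophenyl group, a number 0.70 log units lower from compound 1 to compound 3 (beyond the scatter) as well. The read-out at this position therefore moves both up and down with the group carried there, and of these three rings the one with a hetero atom stands lowest. Nothing at hand accounts for the size of either step. Open, on these data alone, is whether the ring nitrogen or the methyl group carries the fall, and how a morpholine or a carboxylic acid on this carbon would read.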